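This account rests on a few compounds, and the source may have more. Where it says the series, first, only, none or still open, it means among the compounds named here.

Measured so far in a functional assay on SK-MEL-2 cells (Homo sapiens) for cytotoxicity, read by sulforhodamine B assay, with a stated time of 48 h; on this read-out higher numbers stand for weaker inhibition of growth and lower numbers for stronger inhibition of growth:

- compound 1, `ClCc1ccccc1Cn1cnc2c(Cl)ncnc21`: 18200 nM
- compound 2, `ClCc1cccc(Cn2cnc3c(Cl)nc(Cl)nc32)c1`: 4460 nM
- compound 3, `ClCc1ccccc1Cn1cnc2ncnc(Cl)c21`: 19500 nM

Compound 3 gives the highest number of the three in this assay, yet its gap to compound 1 lies within the usual scatter, so the two are not distinguished. Compound 2 stands apart, with a number beyond the scatter lower than that of compound 3, but compound 2 differs from compound 3 in more than one place, so no single step can be read from that pair.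

Compound 4, `ClCc1ccccc1Cn1cnc2nc(Cl)nc(Cl)c21`, differs from compound 3 in one place: chloro in place of hydrogen on an aromatic carbon. Compound 2 already carries a chloro of this kind and is the only one of the three with a clearly lower number, which is the sole hint available. The expected step from compound 3 to compound 4 is therefore a modest move towards stronger inhibition, estimated as a 2.2-fold lower number from compound 3 to compound 4 (0.34 log units; beyond the scatter), with the possibility that it stays within the scatter. For compound 4 the estimate in this assay is 9000 nM, expected to fall between 3500 nM and 22000 nM.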

Compound 4, concentration for total growth inhibition: 5750 nM
Beside the measured number, compound 4's estimate is 1.6-fold (0.19 log units) above it; the range from low to high includes it.
By their numbers in this assay, from the lowest: compounds 2 and 4 (each within the scatter of the next); then compounds 1 and 3 (each within the scatter of the next).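

In this assay, among these compounds, the chloro in place of hydrogen on an aromatic carbon, between two ring nitrogen atoms, gives a 3.4-fold lower number from compound 3 to compound 4 (0.53 log units; beyond the scatter) as the first single-place step. It shows that this position responds to the change, with a modest step towards stronger inhibition of growth that lies beyond the scatter, though this rests on one pair of compounds. Nothing measured here accounts for the step.

On these data alone, whether an amine, a methoxy group or a longer chain on the same carbon would move the number in the same direction, or further, remains open. Also open, as far as these compounds go, is whether the same chloro-for-hydrogen change would give a similar step on the core of compound 1.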